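This account rests on a few compounds, and the source may have more. Where it says the series, first, only, none or still open, it means among the compounds named here.

Going by the values given here, compound 2 `CCCCCOC(=O)C(=O)Nc1cccccc1=O` stands lowest of the two numbers measured so far: in a functional assay on the whole organism (strain Sprague-Dawley CD) for inhibition, with Rattus norvegicus as the target, read by paw edema, at a dose of 30 mg/kg by the intraperitoneal route (a lower number here means a weaker effect, a higher number a stronger effect of the compound at the dose given), compound 2 gives 57%, while compound 1 `CC(C)OC(=O)C(=O)Nc1cccccc1=O` gives 96%, and the only step recorded, a number 39 percentage points lower from compound 1 to compound 2 (beyond the scatter), runs from pentyl in place of isopropyl on an oxygen next to a carbonyl group. Compound 3 `O=C(O)COC(=O)C(=O)Nc1cccccc1=O` is not yet measured; the change from compound 2 is carboxy in place of butyl on a saturated chain carbon bound to an oxygen next to a carbonyl group. The step from compound 1 to compound 2 concerns the same oxygen, so it is the only one that bears here, and it shows the read-out moving by a large amount when that substituent changes. Whether a carboxy group behaves more like the shorter isopropyl ester or like the pentyl chain cannot be read from these two points. The expectation for compound 3 is therefore wide: a step of a number 8 percentage points higher from compound 2 to compound 3 (within the scatter) is expected, giving an estimate of 65% with a range from 35% to 90%.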

Compound 3, a percentage reported as inhibition, in the whole organism at one dose (the size of the read-out at that dose, not a potency): 93%
For compound 3 the middle estimate is 28 percentage points below the measured one; the whole stated range lies below it.
By their numbers in this assay, from the lowest: compound 2; then compounds 3 and 1 (each within the scatter of the next).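

In this assay, the carboxy group on a saturated chain carbon bound to an oxygen next to a carbonyl group restores the read-out lost with the pentyl chain, with a number 36 percentage points higher from compound 2 to compound 3 (beyond the scatter) in the series. Carboxymethyl in place of isopropyl gives a number 3 percentage points lower from compound 1 to compound 3 (within the scatter) and so does not separate the two groups at this dose. Two quite different substituents on this oxygen thus read alike, with compound 2 alone apart from both, and nothing measured here bears on why the read-out moves.

From the compounds shown here alone, whether a straight ethyl or butyl chain falls with pentyl or stays with isopropyl remains open. So does whether the carboxylic acid itself matters, which a methyl ester or a primary amide of the carboxymethyl group would test.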